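Working notes: aryl swap on an amide-type nitrogen

A few compounds are considered here, and "the series" means these few. Any claim that something is new, unique, unknown or untested is made for them only; others in the source may bear on it.

Measured so far:
- compound 1 `CN(C)C(=O)c1cc2cnc(Nc3ccc(N)cn3)nc2n1C1CCCC1` gives 82.1%
- compound 2 `CN(C)C(=O)c1cc2cnc(Nc3ccc(NC(=O)C4(C(=O)Nc5ccc(Cl)cc5)CC4)cc3)nc2n1C1CCCC1` gives 88.6%

Both values come from a functional assay on NCI-H1299 cells (Homo sapiens) for inhibition, read by CCK-8 assay, with a stated time of 72 h, tested at 10 uM (on this read-out higher numbers stand for more inhibition of growth at the one concentration tested and lower numbers for less inhibition of growth), and lie within the scatter of each other. Among the compounds with values here, compound 2 therefore stands level with the only other measured compound, and neither can be ranked.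

The next compound is compound 3 `CN(C)C(=O)c1cc2cnc(Nc3ccc(NC(=O)C4(C(=O)Nc5cccc(O)c5)CC4)cc3)nc2n1C1CCCC1`. It differs from compound 2 as follows: 3-hydroxyphenyl in place of 4-chlorophenyl on an amide-type nitrogen. In words, 3-hydroxyphenyl stands in place of 4-chlorophenyl on an amide-type nitrogen.

Within the data shown here, no measured pair differs in one place only, so the data hold no direct guide to this exchange. The structures of the two measured compounds differ widely, yet compound 1 gives 82.1% and compound 2 gives 88.6% in this assay. On that basis a large drop is not expected. The expected step of a number 7.6 percentage points lower from compound 2 to compound 3 (within the scatter) is a small fall that does not clearly leave the scatter. The estimated value for compound 3 is 81% (expected range 62% to 93%).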

Compound 3, percent growth inhibition at one concentration: 78.5%
For compound 3 the middle estimate is 2.5 percentage points above the measured one, within the range that was stated.
By their numbers in this assay, from the lowest: compounds 3, 1 and 2 (each within the scatter of the next, the first and the last beyond it).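

Within the data shown here, on the amide-type nitrogen, the exchange of 4-chlorophenyl for 3-hydroxyphenyl gives the first change in one place, and in this assay it reads as a number 10.1 percentage points lower from compound 2 to compound 3 (beyond the scatter), so this position responds to the aryl group, although compound 3 still gives 78.5% at the one concentration tested. The entering group carries a hydrogen-bond donor and a hydrogen-bond acceptor that the leaving group lacks, and the substituent and its numbered place on the phenyl ring change together, so this one step cannot be assigned to either change alone. No measurement of any property bears on this step, and it remains without an explanation.

Open, on these data alone, is whether the step follows the substituent or its place on the ring, a question that 3-chlorophenyl or 4-hydroxyphenyl on the same nitrogen would address. Also open is how this position responds to other groups, such as 3-aminophenyl, 3-carboxyphenyl or a pyridyl ring, since the compounds shown hold only these two aryl groups here.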